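The source may hold more compounds than are shown below. What is called first, only, known or untested is meant among the compounds shown, and "the series" means these compounds.

Of the compounds shown here, two built on the same core have been measured in a functional assay on CCRF-CEM cells (Homo sapiens) for antiproliferative activity, read by MTT assay, with a stated time of 48 h, tested at 25 uM; a higher number here means a weaker effect of the compound at the concentration tested, a lower number a stronger effect. Compound 1 `OC(CCn1nc2c(Br)c(Br)c(Br)c(Br)c2n1)c1ccc(F)cc1` gives 88% in this assay. Compound 2 `OC(CCn1nc2c(Br)c(Br)c(Br)c(Br)c2n1)c1ccccc1` gives 84% in this assay. Among the measured compounds shown here, the only step between them, a number 4 percentage points lower from compound 1 to compound 2 (within the scatter), comes from hydrogen in place of fluoro on an aromatic carbon and stays within the scatter. Compound 2 thus holds the lower of the two numbers, with compound 1 as its nearest neighbour, but the gap between them is within the scatter, so no order between the two can be read from it.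

Compound 3 `OC(CCn1nc2c(Br)c(Br)c(Br)c(Br)c2n1)c1ccc(Br)cc1` has not yet been measured in this assay. It differs from compound 2 by bromo in place of hydrogen on an aromatic carbon. For the measured compounds named here, the one measured step that bears on this change, a number 4 percentage points lower from compound 1 to compound 2 (within the scatter), swapped a halogen for hydrogen at the same kind of place and stayed within the scatter. The expected step of a number 2 percentage points higher from compound 2 to compound 3 (within the scatter) is therefore no change beyond the scatter, in no firm direction. Compound 3 is estimated at 86%, with a range from 74% to 98%.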

Compound 3, a percentage reported as activity, at one concentration (the size of the read-out at that concentration, not a potency): 69%
The estimate for compound 3 lay 17 percentage points above the measured number, outside the stated range (below it).
By their numbers in this assay, from the lowest: compound 3; then compounds 2 and 1 (each within the scatter of the next).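

In this assay, among the compounds shown here, the ring carbon carrying this substituent is no longer silent: bromo in place of hydrogen gives a number 15 percentage points lower from compound 2 to compound 3 (beyond the scatter) and is the first change to pass beyond the scatter. Bromo in place of fluoro gives a number 19 percentage points lower from compound 1 to compound 3 (beyond the scatter) while the fluoro of compound 1 and the hydrogen of compound 2 remain indistinguishable, so the two halogens do not behave alike here and a halogen at this place does not by itself bring a step beyond the scatter. Compound 3, with its 4-bromophenyl group, thus shows the strongest effect of the three at the concentration tested, but nothing at hand explains why bromo stands apart from fluoro and hydrogen.

Going by these compounds, it remains open whether chloro or iodo at the same place would follow bromo or stay with fluoro, and whether a methyl, a methoxy or an amine there would give a step of similar size. Also open, on these data alone, are whether the step survives a ketone in place of the hydroxyl or a longer chain, and whether it would hold at concentrations other than the single one used for this read-out.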